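Trifluoromethyl to Methyl on a Saturated Ring Carbon

A few compounds are considered here, and "the series" means these few. Any claim that something is new, unique, unknown or untested is made for them only; others in the source may bear on it.

Among the compounds with values here, compound 1 `COc1ccc(Cl)cc1NC(=O)[C@@H](C)N1CCN(S(=O)(=O)N2CCC(C(F)(F)F)CC2)CC1` is the only compound here with a numerical result in an assay on HEK293 cells for inhibition of potassium channel subfamily T member 1 (Homo sapiens), read by thallium flux (a higher number here means a weaker inhibitor, a lower number a stronger inhibitor), where compound 1 gives 3500 nM. Compound 2 `CCCC1CCN(C(=O)N2CCN(S(=O)(=O)N3CCN(CC(=O)Nc4cc(Cl)ccc4OC)CC3)CC2)CC1` reaches only the limit of this assay, giving > 10000 nM. Compound 3 `COc1ccc(Cl)cc1NC(=O)[C@@H](C)N1CCN(S(=O)(=O)N2CCC(C)CC2)CC1` differs from compound 1 by methyl in place of trifluoromethyl on a saturated ring carbon. Within the data shown here, no measured pair shows what this change does, so its direction is uncertain; a modest loss of potency, around the edge of the scatter, seems the more likely outcome. Compound 3 is therefore expected to give about 6000 nM, between 2000 nM and 20000 nM, an expected step of a 1.7-fold higher number from compound 1 to compound 3 (0.23 log units; within the scatter).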

Compound 3, half-maximal inhibitory concentration: 4900 nM
Compound 3: the middle estimate sits 1.2-fold (0.09 log units) above what was measured; measured number inside the range.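

Replacing 4-(trifluoromethyl)piperidin-1-yl with 4-methylpiperidin-1-yl gives a 1.4-fold higher number from compound 1 to compound 3 (0.15 log units; within the scatter) in this assay. This ring carbon therefore keeps its measured activity without the three fluorine atoms, and the two groups cannot be told apart here. Nothing shown gives a reason for this result.

From the compounds shown here alone, whether an amine, a carboxylic acid or a longer chain on this ring carbon would move the number beyond the scatter remains open. So does the outcome with plain hydrogen in place of the methyl.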